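From compound 2 to compound 3: a difluoromethoxy swap

A few compounds are considered here, and "the series" means these few. Any claim that something is new, unique, unknown or untested is made for them only; others in the source may bear on it.

Of the compounds shown here, two on the shared core have been read in a toxicity assay on MDCK cells (Canis lupus familiaris) for cytotoxicity, read by crystal violet staining, with a stated time of 48 h; on this read-out lower numbers stand for higher toxicity in this test and higher numbers for lower toxicity in this test. Compound 1 `CCc1ccc2[nH]c(=O)c(CN(Cc3ccc(C(C)(C)C)cc3)[C@H](CO)c3ccccc3)cc2c1` gives > 10000 nM, and this value is a limit. Compound 2 `CCc1ccc2[nH]c(=O)c(CN(Cc3ccc(C(C)(C)C)cc3)[C@@H](C)c3ccc(F)cc3)cc2c1` gives > 5000 nM, and this value is also a limit. Compound 2 therefore has no numerical standing in this assay, and neither value shown for the series is a number.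

Compound 3 `CCc1ccc2[nH]c(=O)c(CN(Cc3ccc(C(C)(C)C)cc3)C(C)c3ccc(OC(F)F)cc3)cc2c1` carries 1-(4-(difluoromethoxy)phenyl)ethyl in place of 1-(4-fluorophenyl)ethyl on an amine nitrogen.

Among the measured compounds shown here, only one measured step bears on this change. It also alters a group on the amine nitrogen, but a step that the two limits leave unreadable from compound 1 to compound 2 offers neither a size nor a direction to carry over. No step beyond the usual scatter is therefore expected in this assay, and no direction is favoured.

The expected step is a step that the limit leaves unreadable from compound 2 to compound 3. For compound 3 the estimated value is 7000 nM, with an expected range of 2500 nM to 20000 nM. A report as a limit alone is the more likely outcome.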

Compound 3, half-maximal cytotoxic concentration: > 5000 nM
Compound 3: no number, only a limit; the forecaster's own chance of this, stated with the estimate: 70%; the middle value is on the limit's open side.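

No new step can be read in this assay from compound 2 to compound 3, or from compound 1 to compound 3, because all of these values are limits only: the limit of > 5000 nM in this assay, at which 2 of the 3 values shown sit.

The compounds shown leave open whether any change of group on the amine nitrogen moves the half-maximal cytotoxic concentration at all.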